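The source may hold more compounds than are shown below. What is called first, only, known or untested is meant among the compounds shown, and "the series" means these compounds.

Measured compounds: compound 1 `C[C@H](CCO)CC[C@@H]1[C@@]2(C)CCCC(C)(C)[C@@H]2CC[C@@]1(C)O`, 15000 nM; compound 2 `CC(=O)OCC[C@@H](C)CC[C@@H]1[C@@]2(C)CCCC(C)(C)[C@@H]2CC[C@@]1(C)O`, 15000 nM; compound 3 `C[C@@H](CC[C@@H]1[C@@]2(C)CCCC(C)(C)[C@@H]2CC[C@@]1(C)O)CC(=O)O`, > 50000 nM.

In a functional assay on RAW264.7 cells (Mus musculus) for inhibition, read by Griess assay, with stated times of 30 min and 24 h (on this read-out higher numbers stand for weaker inhibition and lower numbers for stronger inhibition), compound 1 gives 15000 nM and compound 2 gives 15000 nM. For compound 3 the assay reports only a limit, (the limit of > 50000 nM in this assay, at which 1 of the 3 values shown sits), not a number. Compound 3 therefore stands at the weak end of the three: an at least 3.3-fold higher number from compound 1 to compound 3 (0.52 log units; beyond the scatter) and an at least 3.3-fold higher number from compound 2 to compound 3 (0.52 log units; beyond the scatter). Compound 4 `COC(=O)C[C@@H](C)CC[C@@H]1[C@@]2(C)CCCC(C)(C)[C@@H]2CC[C@@]1(C)O` differs from compound 3 by methyl in place of hydrogen on an oxygen next to a carbonyl group. The measured step closest in kind is no change at the digits printed from compound 1 to compound 2 (within the scatter), where acetyl in place of hydrogen on an oxygen left the number where it was. Compound 4 carries an ester, as compound 2 does, while compound 3 carries a carboxy group. The step is therefore expected to be an at least 2.0-fold lower number from compound 3 to compound 4 (0.30 log units; that floor lies within the scatter), though the limit for compound 3 leaves its true size uncertain. Compound 4 is estimated at 25000 nM, between 8000 nM and 80000 nM.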

Compound 4, half-maximal inhibitory concentration: 5000 nM
Beside the measured number, compound 4's estimate is 5.0-fold (0.70 log units) above it; the measured number lies below the stated range.
By their numbers in this assay, from the lowest: compound 4; then compounds 1 and 2 (each within the scatter of the next). At a limit, above all of these: compound 3.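

In this assay, methyl in place of hydrogen on the oxygen of the carboxy group gives an at least 10-fold lower number from compound 3 to compound 4 (1.00 log units; beyond the scatter), so the free acid and its methyl ester differ clearly at this position. As far as these compounds go, the value for compound 3 is only a limit, and the true size of that step stays unknown: the limit of > 50000 nM in this assay, at which 1 of the 4 values shown sits. The methoxycarbonyl group also beats the earlier chain ends, with a 3.0-fold lower number from compound 1 to compound 4 (0.48 log units; beyond the scatter) and a 3.0-fold lower number from compound 2 to compound 4 (0.48 log units; beyond the scatter), a gain that acetylation of the alcohol did not bring.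

From the compounds shown here alone, whether an ethyl ester or an amide at this position would lower the number further remains open.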